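This account rests on a few compounds, and the source may have more. Where it says the series, first, only, none or still open, it means among the compounds named here.

Measured so far in an assay on HEK293 cells for inhibition of protein kinase C zeta type (Homo sapiens), read by 33P incorporation, with a stated time of 40 min, tested at 20 uM, in the presence of a further agent that is not named here; on this read-out higher numbers stand for more inhibition at the one concentration tested (going by the name of the read-out) and lower numbers for less inhibition:

compound 1, `COc1ccc(C2=NN(c3ccc(Cl)cc3)C(c3ccc(Cl)cc3)C2)cc1OC`: 39.4%
compound 2, `COc1ccc(C2=NN(c3cccc(Cl)c3)C(c3cccc(Cl)c3)C2)cc1`: 25.3%
compound 3, `COc1ccc(C2=NN(c3ccc(Cl)cc3)C(c3ccc(Cl)cc3)C2)cc1`: 23%

Compound 3 sits at the low end of the three numbers. Compound 2 lies within the scatter of it, so the two cannot be told apart; compound 1 stands beyond the scatter above it. Among the compounds with values here, the only step between compounds that differ in one place is a number 16.4 percentage points lower from compound 1 to compound 3 (beyond the scatter), and it concerns the methoxy group, not the chlorophenyl rings.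

Compound 4, `COc1ccc(C2=NN(c3ccc(Cl)cc3)C(c3cccc(Cl)c3)C2)cc1`, differs from compound 3 in one place: 3-chlorophenyl in place of 4-chlorophenyl on a saturated ring carbon. Within the data shown here, no measured step bears directly on this change. Among the measured compounds shown here, compound 2 and compound 3 differ in both chlorophenyl rings at once, not in one place, so no step is recorded for them; their two values simply lie within the scatter of each other. With nothing in the measured set pointing to a move in either direction, the expectation for the step of a number 1 percentage points higher from compound 3 to compound 4 (within the scatter) is no change beyond the scatter. Compound 4 is therefore expected to give about 24% in this assay, with a range from 13% to 35%.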

Compound 4, a percentage reported as inhibition, at one concentration (the size of the read-out at that concentration, not a potency): 39%
Estimate against measurement, compound 4: 15 percentage points below; measured number above the stated range.
By their numbers in this assay, from the lowest: compounds 3 and 2 (each within the scatter of the next); then compounds 4 and 1 (each within the scatter of the next).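

Placing 3-chlorophenyl in place of 4-chlorophenyl on the saturated ring carbon gives a number 16 percentage points higher from compound 3 to compound 4 (beyond the scatter) in this assay, so this position responds to the change between these two chlorophenyl groups, something the earlier compounds could not show because compound 2 and compound 3 differ in both chlorophenyl rings at once. The second step, with 3-chlorophenyl held on the saturated ring carbon and 4-chlorophenyl in place of 3-chlorophenyl on the amine nitrogen in the ring, gives a number 13.7 percentage points higher from compound 2 to compound 4 (beyond the scatter), so the ring nitrogen also responds to this change, and the closeness of the printed values of compound 2 and compound 3 concealed two separate single-place steps. Nothing available explains why either chlorophenyl change moves the number.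

Still open, from the compounds shown here alone, is whether the methoxy step, a number 16.4 percentage points lower from compound 1 to compound 3 (beyond the scatter), would carry over to the core of compound 4 with the same size. Also open, going by these compounds, is whether the number would be higher, lower or level with a different substituent on the phenyl ring on the saturated ring carbon, such as an amine or a carboxylic acid in place of the chlorine.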